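Removing the chloro substituent from the anilide ring of compound 1

The source may report more compounds than this note shows. Statements on the series, on what has been measured and on what is new or still open speak of the compounds shown alone.

Compound 1, `COc1cc([C@H]2C[C@]2(CO)C(=O)Nc2ccccc2Cl)cc(OC)c1OC`, gives 45500 nM in a functional assay on HeLa cells (Homo sapiens) for cytotoxicity, read by MTT assay, with a stated time of 48 h; on this read-out lower numbers stand for stronger inhibition and higher numbers for weaker inhibition. Among the numbers shown it stands highest; its mirror image, compound 3, `COc1cc([C@@H]2C[C@@]2(CO)C(=O)Nc2ccccc2Cl)cc(OC)c1OC`, gives 13300 nM, and the step of a 3.4-fold lower number from compound 1 to compound 3 (0.53 log units; beyond the scatter) is of modest size, because of the fact that compounds 1 and 3 differ only in the configuration as drawn. Compound 2, `CCOC(=O)[C@]1(C(=O)Nc2ccccc2Cl)C[C@@H]1c1cc(OC)c(OC)c(OC)c1`, reports only a limit, > 100000 nM, in this assay. The step of an at least 2.1-fold higher number from compound 1 to compound 2 (0.34 log units; beyond the scatter) goes toward weaker inhibition.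

Compound 4, `COc1cc([C@H]2C[C@]2(CO)C(=O)Nc2ccccc2)cc(OC)c1OC`, differs from compound 1 by hydrogen in place of chloro on an aromatic carbon. Neither measured step touches the anilide ring: one alters the hydroxymethyl on the saturated ring, the other only the configuration. So no measured comparison shows the effect of removing the chloro group, and the expectation rests on the small spread of the numbers seen so far. A step of a 1.2-fold higher number from compound 1 to compound 4 (0.08 log units; within the scatter) is expected, likely within the scatter or at most modest in either direction. Compound 4 is therefore estimated at 55000 nM, with a range from 18000 nM to 150000 nM.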

Compound 4, half-maximal inhibitory concentration: > 100000 nM
Compound 4 ended at the assay's limit (the forecaster's own chance of this, stated with the estimate: 30%); middle value at least 1.8-fold (0.25 log units) from the limit.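

Among these compounds, the earlier steps changed only the hydroxymethyl group and the configuration, so this is the first measured change on the anilide ring. Going from 2-chlorophenyl to phenyl, with hydrogen in place of chloro, gives an at least 2.1-fold higher number from compound 1 to compound 4 (0.34 log units; beyond the scatter), so losing this one chlorine atom moves the result toward weaker inhibition in this assay. Compound 4 sits at a limit and not at a number, which leaves the full size of the step unknown: the limit of > 100000 nM in this assay, at which 2 of the 4 values shown sit.

As far as these compounds go, whether a fluoro, bromo, methyl or methoxy group at this place would match the chloro group remains open. So does whether compound 3, the mirror image of compound 1, would respond in the same way to losing its chloro group.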